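The source may hold more compounds than are shown below. What is called first, only, known or untested is meant among the compounds shown, and "the series" means these compounds.

Compound 1 `COc1cc(-c2nnc3n2NC(c2cccs2)C(C(=O)c2ccccc2)S3)cc(OC)c1OC` and compound 2 `COc1cc(-c2nnc3n2NC(c2cccs2)C(C(=O)c2ccc(C)cc2)S3)cc(OC)c1OC` share one core and differ in a single place. In a functional assay on HepG2 cells (Homo sapiens) for cytotoxicity, read by MTT assay, with a stated time of 48 h (on this read-out lower numbers stand for stronger inhibition and higher numbers for weaker inhibition), compound 1 reaches only the limit of the assay, > 100000 nM. Compound 2 gives 3700 nM, so an at least 27-fold lower number from compound 1 to compound 2 (1.43 log units; beyond the scatter). Compound 3 `COc1cc(-c2nnc3n2NC(c2ccco2)C(C(=O)c2ccc(F)c(F)c2)S3)cc(OC)c1OC` gives 52400 nM, the highest of the two numbers recorded. Compound 4 `COc1cc(-c2nnc3n2NC(c2ccco2)C(C(=O)c2ccco2)S3)cc(OC)c1OC` is the next step: furan-2-yl in place of 3,4-difluorophenyl on a carbonyl carbon. Among the compounds with values here, the only measured step concerns a different change, methyl in place of hydrogen on an aromatic carbon, and says nothing direct about this swap; it shows only that small changes can shift the number strongly. The expected step is therefore uncertain, put at a 1.3-fold lower number from compound 3 to compound 4 (0.12 log units; within the scatter), leaning toward little change. Compound 4 is estimated at 40000 nM, with a range from 8000 nM to 100000 nM.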

Compound 4, half-maximal inhibitory concentration: > 100000 nM
Compound 4: only a limit was reported; the forecaster's own chance of this, stated with the estimate: 30%; at least 2.5-fold (0.39 log units) between middle value and limit.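

Replacing 3,4-difluorophenyl with furan-2-yl on a carbonyl carbon gives an at least 1.9-fold higher number from compound 3 to compound 4 (0.28 log units; that floor lies within the scatter). The earlier step only added a methyl to the aromatic ring on this carbonyl, whereas here the whole ring is exchanged, and the number does not fall. The size of this step cannot be read, because the value of compound 4 is a limit of the assay: the limit of > 100000 nM in this assay, at which 2 of the 4 values shown sit.

On these data alone, it remains open whether a methyl on the furan-2-yl would lower the number as it did on the phenyl ring. As far as these compounds go, the effect of an amine or a carboxylic acid on the ring at this carbonyl also remains open.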